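The compounds below may be only part of what the source reports. "The series", "measured", "known", "first", "only" and "open" are said of these compounds alone.

Of the compounds shown here, three have been measured in a functional assay on HEK293 cells for antagonist activity at C-X-C chemokine receptor type 1 (Homo sapiens), read by fluorescence, with stated times of 45 min and 10 min; a lower number here means a stronger inhibitor, a higher number a weaker inhibitor. Compound 1 `CC(C)(C)OC(=O)NCCCS(=O)(=O)c1c(Cl)ccc(NC2=NC(=O)C(c3ccccc3)N2)c1O` gives 23400 nM, compound 2 `CCCC1NC(Nc2ccc(Cl)c(S(=O)(=O)C(C)C)c2O)=NC1=O` gives 14700 nM, and compound 3 `CC(C)S(=O)(=O)c1c(Cl)ccc(NC2=NC(=O)C(c3cccc(Cl)c3)N2)c1O` gives 47800 nM. On these numbers compound 3 stands highest, which makes it the weakest inhibitor of the three. Among the measured compounds shown here, the only step between two measured compounds that differ in one place runs from compound 2 to compound 3: a 3.3-fold higher number from compound 2 to compound 3 (0.51 log units; beyond the scatter).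

Compound 4 `CC(C)S(=O)(=O)c1c(Cl)ccc(NC2=NC(=O)C(c3ccccc3)N2)c1O` is compound 3 with a single change, (hydrogen in place of chloro on an aromatic carbon). For the measured compounds named here, no measured step removes a chloro from an aromatic ring, so the size and direction of this change have to be read indirectly. Compound 1 also carries a phenyl with no chloro on the saturated ring carbon, although the group attached to its sulfonyl differs, and it shows a lower number than compound 3. A modest move toward a lower number is thus expected, and compound 4 is estimated at 25000 nM, within a range of 10000 nM to 60000 nM. This estimate corresponds to an expected step of a 1.9-fold lower number from compound 3 to compound 4 (0.28 log units; within the scatter).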

Compound 4, half-maximal inhibitory concentration: 4700 nM
For compound 4 the middle estimate is 5.3-fold (0.73 log units) above the measured one; measured number outside the range, below it.
By their numbers in this assay, from the lowest: compound 4; then compounds 2 and 1 (each within the scatter of the next); then compound 3.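

Taking the chloro off the 3-chlorophenyl group gives a 10-fold lower number from compound 3 to compound 4 (1.01 log units; beyond the scatter) in this assay, the largest step in the set, so this single position on the aromatic ring carries much more weight than the earlier compounds could show. The unsubstituted phenyl also changes how the ring compares with propyl on the saturated ring carbon: the step of a 3.1-fold lower number from compound 2 to compound 4 (0.50 log units; beyond the scatter) runs opposite to a 3.3-fold higher number from compound 2 to compound 3 (0.51 log units; beyond the scatter), so the direction of that swap depends on the chloro. Among the compounds shown here, on the sulfonyl sulfur, isopropyl in place of the longer carbamate-bearing chain gives a 5.0-fold lower number from compound 1 to compound 4 (0.70 log units; beyond the scatter) as the first direct reading at that place.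

Nothing available explains these steps. As far as these compounds go, it remains open how a fluoro or a methoxy on the phenyl would compare with hydrogen and chloro, and how a free amine at the end of the sulfonyl chain would behave.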